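This account rests on a few compounds, and the source may have more. Where it says the series, first, only, none or still open, it means among the compounds named here.

In a functional assay on MKN-28 cells (Homo sapiens) for inhibition, read by colorimetric assay and sulforhodamine B assay, with a stated time of 48 h (a higher number here means a weaker inhibitor of growth, a lower number a stronger inhibitor of growth), compound 1 `CCCCCCCCCCCC[C@@H](O)[C@H]1CC[C@H]([C@H](O)CCCCCCCCCCNC(=O)c2cccs2)O1` gives 363 nM and compound 2 `CCCCCCCCCCCC[C@@H](O)[C@H]1CC[C@H]([C@H](O)CCCCCCCCCCNC(=O)c2ccco2)O1` gives 617 nM, two values within the scatter of each other. Compound 3 `CCCCCCCCCCCC[C@@H](O)[C@H]1CC[C@H]([C@H](O)CCCCCCCCCCNC(=O)c2ccoc2)O1` is still unmeasured. It differs from compound 2 by furan-3-yl in place of furan-2-yl on a carbonyl carbon, with furan-3-yl in place of furan-2-yl on a carbonyl carbon. Among the measured compounds shown here, the only measured step that bears on this change is the one at the same place, a 1.7-fold higher number from compound 1 to compound 2 (0.23 log units; within the scatter), which stayed within the scatter. No shift beyond the scatter is therefore expected in this assay, in either direction. The expected step is a 1.2-fold lower number from compound 2 to compound 3 (0.07 log units; within the scatter). For compound 3 the estimated value is 520 nM, with an expected range of 230 nM to 1200 nM.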

Compound 3, concentration for 50% growth inhibition: 550 nM
Beside the measured number, compound 3's estimate is 1.1-fold (0.02 log units) below it; the measured number falls inside the stated range.
By their numbers in this assay, from the lowest: compounds 1, 3 and 2 (each within the scatter of the next).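

Exchanging furan-2-yl for furan-3-yl on a carbonyl carbon gives a 1.1-fold lower number from compound 2 to compound 3 (0.05 log units; within the scatter) in this assay, so changing the furan's point of attachment at this position leaves the number within the scatter. Furan-3-yl in place of thiophen-2-yl gives a 1.5-fold higher number from compound 1 to compound 3 (0.18 log units; within the scatter), which places all three five-membered aromatic rings within the scatter of one another. Nothing available accounts for this result.

The compounds shown leave open whether a phenyl ring, a pyridine ring or a plain alkyl chain on the same carbonyl carbon would shift the number beyond the scatter.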